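Swapping 3,4-dichlorophenyl for thiophen-3-yl

The source may report more compounds than this note shows. Statements on the series, on what has been measured and on what is new or still open speak of the compounds shown alone.

Of the compounds shown here, three sharing one core have been tested in a functional assay on CCRF-CEM cells (Homo sapiens) for antiproliferative activity; on this read-out higher numbers stand for weaker inhibition and lower numbers for stronger inhibition. Compound 1 `COc1cc(C(=O)c2sc(-c3cccc([N+](=O)[O-])c3)cc2N)cc(OC)c1OC`, carrying 3-nitrophenyl, gives 5.9 nM, and compound 2 `COc1cc(C(=O)c2sc(-c3ccccc3Cl)cc2N)cc(OC)c1OC`, carrying 2-chlorophenyl, gives 16 nM. Compound 3 `COc1cc(C(=O)c2sc(-c3ccc(Cl)c(Cl)c3)cc2N)cc(OC)c1OC`, carrying 3,4-dichlorophenyl, gives 290 nM, the highest number of the three and therefore the weakest inhibition.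

Compound 4 `COc1cc(C(=O)c2sc(-c3ccsc3)cc2N)cc(OC)c1OC` has thiophen-3-yl in place of 3,4-dichlorophenyl on an aromatic carbon.

Within the data shown here, no tested pair makes this exact swap, so the nearest evidence is the exchange of one aromatic group for another at the same place. Two such exchanges were large, a 49-fold higher number from compound 1 to compound 3 (1.69 log units; beyond the scatter) and an 18-fold higher number from compound 2 to compound 3 (1.26 log units; beyond the scatter), while the third was modest, a 2.7-fold higher number from compound 1 to compound 2 (0.43 log units; beyond the scatter). Compound 3 is thus the outlier, and compound 4 no longer carries its two chlorines. However, no five-membered ring has been tested at this place, so the uncertainty is wide.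

A clear move to a lower number is expected, a 7.3-fold lower number from compound 3 to compound 4 (0.86 log units; beyond the scatter). For compound 4 the estimated value is 40 nM, with an expected range from 8 nM to 200 nM.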

Compound 4, half-maximal inhibitory concentration: 9.6 nM
The estimate for compound 4 lay 4.2-fold (0.62 log units) above the measured number; the range from low to high includes it.
By their numbers in this assay, from the lowest: compounds 1, 4 and 2 (each within the scatter of the next, the first and the last beyond it); then compound 3.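

In this assay, thiophen-3-yl brings a 30-fold lower number from compound 3 to compound 4 (1.48 log units; beyond the scatter), which shows that this position accepts a five-membered aromatic ring with a sulfur, not only a six-membered ring of carbon. Compound 4 also cannot be told apart from either of the two better compounds, with a 1.7-fold lower number from compound 2 to compound 4 (0.22 log units; within the scatter) and a 1.6-fold higher number from compound 1 to compound 4 (0.21 log units; within the scatter), so a ring with neither a nitro group nor a chlorine can match both of them, and compound 3 stands alone among the four. Nothing measured here explains why the swap has such a large effect.

From the compounds shown here alone, it remains open how a ring bearing an amine or a carboxylic acid, or a longer alkyl chain in place of a ring, would behave here. Going by these compounds, it is also open whether one chlorine of 3,4-dichlorophenyl alone would give a number as high as that of compound 3.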